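Swapping a hydroxy for a chloro on the pendant ring

A few compounds are considered here, and "the series" means these few. Any claim that something is new, unique, unknown or untested is made for them only; others in the source may bear on it.

The measured compounds, with their values in an assay on cells for displacement of a labelled ligand from adenosine receptor A3 (Homo sapiens), read by scintillation counting and radioligand binding, with a stated time of 180 min, tested at 10 uM; a lower number here means less inhibition, a higher number more inhibition at the concentration tested (going by the name of the read-out):
- compound 1 `Cn1cnc2c(N3CCCCC3)nc(-c3cccc(O)c3O)nc21`: 33.7%
- compound 2 `Cn1cnc2c(N3CCCCC3)nc(-c3cc(Cl)ccc3Cl)nc21`: 5.4%
- compound 3 `Cn1cnc2c(N3CCCCC3)nc(-c3cccc(O)c3)nc21`: 49.1%

Compound 3 stands highest of the three numbers. Its nearest neighbour is compound 1, reached by a number 15.4 percentage points higher from compound 1 to compound 3 (beyond the scatter); its furthest is compound 2, reached by a number 43.7 percentage points higher from compound 2 to compound 3 (beyond the scatter).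

Compound 4 `Cn1cnc2c(N3CCCCC3)nc(-c3cccc(Cl)c3)nc21` differs from compound 3 in one place: chloro in place of hydroxy on an aromatic carbon.

Among the measured compounds shown here, two measured steps bear on this change. The step of a number 43.7 percentage points higher from compound 2 to compound 3 (beyond the scatter) shows that a ring carrying two chloro groups sits far below the ring carrying a single hydroxy group, while a number 15.4 percentage points higher from compound 1 to compound 3 (beyond the scatter) shows that removing one hydroxy group raised the number only modestly. Compound 4 carries one chloro and no hydroxy, so the account expects the number to fall from compound 3, though less sharply than it did for compound 2, because compound 2 with 5.4% carries two chloro groups rather than one. The expected step is a number 21.1 percentage points lower from compound 3 to compound 4 (beyond the scatter). For compound 4 the estimate in this assay is 28%, expected to lie between 8% and 50%.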

Compound 4, a percentage reported as inhibition, at one concentration (the size of the read-out at that concentration, not a potency): 6.1%
Beside the measured number, compound 4's estimate is 21.9 percentage points above it; the whole stated range lies above it.
By their numbers in this assay, from the lowest: compounds 2 and 4 (each within the scatter of the next); then compound 1; then compound 3.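

In this assay, the change from 3-hydroxyphenyl to 3-chlorophenyl alone gives a number 43 percentage points lower from compound 3 to compound 4 (beyond the scatter) and so, at this position, chloro does not stand in for hydroxy. Among the compounds shown here, with a number 0.7 percentage points higher from compound 2 to compound 4 (within the scatter), the single chloro leaves compound 4 level with the dichlorinated compound 2, so the low number does not need a second chloro group. With a number 27.6 percentage points lower from compound 1 to compound 4 (beyond the scatter), compound 4 also falls short of the dihydroxy compound 1, and among these four compounds both rings carrying hydroxy stand above both rings carrying chloro, with no exception.

Going by these compounds, whether the number at this position follows the hydroxy group itself remains open, as a methoxy group, an amine or a bare phenyl ring could show. The data at hand offer no explanation for the size of this drop.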